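This account rests on a few compounds, and the source may have more. Where it says the series, first, only, none or still open, it means among the compounds named here.

Measured compounds:
- compound 1 `CCOc1ccc2nc(Cl)c(/C=C3\SC(=S)NC3=O)cc2c1`: > 100 ug/mL
- compound 2 `COc1ccc2cc(/C=C3\SC(=S)NC3=O)c(Cl)nc2c1`: > 100 ug/mL

In a toxicity assay on PANC-1 cells (Homo sapiens) for cytotoxicity, read by MTT assay, with a stated time of 48 h (on this read-out higher numbers stand for weaker inhibition of growth and lower numbers for stronger inhibition of growth), compound 1 gives > 100 ug/mL, which is a limit of the assay and not a number. Compound 2 gives > 100 ug/mL, which is also a limit. The whole measured series therefore stands at one ceiling: the limit of > 100 ug/mL in this assay, at which 2 of the 2 values shown sit. Among the compounds with values here, neither compound has a numerical value, so the series offers no measured step to scale from.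

The next compound is compound 3 `COc1ccc2nc(Cl)c(/C=C3\SC(=S)NC3=O)cc2c1`. It differs from compound 1 by a single change, hydrogen in place of methyl on a saturated chain carbon bound to an oxygen on an aromatic ring, which turns ethoxy to methoxy.

No step beyond the usual scatter is expected in this assay, in either direction. This expectation rests on compound 1, with its limit of > 100 ug/mL, and on the small size of the change. The expected size of a number no higher from compound 1 to compound 3 (the limit leaves the size open) is accordingly within the scatter. Another report of a limit rather than a number is also expected. For compound 3 the estimated value is 100 ug/mL, with an expected range of 50 ug/mL to 200 ug/mL.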

Compound 3, concentration for 50% growth inhibition: > 100 ug/mL
Compound 3 ended at the assay's limit; the forecaster's own chance of this, stated with the estimate: 85%; the middle value sits exactly at the limit.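

In this assay compound 3 gives > 100 ug/mL, a limit and not a number. Compound 1 also stands at a limit, so no step can be read between compound 1 and compound 3. The compounds shown leave open how far any of them lies past the ceiling, and what a change in this series does to growth inhibition: the limit of > 100 ug/mL in this assay, at which 3 of the 3 values shown sit.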